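Selenocyanate series, working notes toward compound 4

The source may report more compounds than this note shows. Statements on the series, on what has been measured and on what is new or still open speak of the compounds shown alone.

Measured so far:
compound 1: `COc1ccc(N(C)c2nc(C)nc3ccccc23)cc1C(=O)NCC[Se]C#N` — 313 nM in a functional assay on HCT-116 cells (Homo sapiens) for inhibition, read by MTT assay, with a stated time of 48 h; a lower number here means a stronger inhibitor, a higher number a weaker inhibitor
compound 2: `Cc1nc(N(C)c2ccc([Se]C#N)c(F)c2)c2ccccc2n1` — 20 nM
compound 3: `CN(c1ccc([Se]C#N)cc1)c1nc(C2CC2)nc2ccccc12` — 62 nM

Compound 1 stands at the highest number of the three. Its nearest neighbour is compound 3, whose number lies lower by more than the scatter; compound 2 lies further away still, also beyond the scatter. Neither compound 2 nor compound 3 differs from compound 1 in a single place, so their values show only that both are stronger inhibitors than compound 1 in this assay, not which part of the structure carries that difference.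

The next compound is compound 4, `COc1ccc(N(C)c2nc(C)nc3ccccc23)cc1OCCCC[Se]C#N`. Relative to compound 1 it carries a group of 8 heavy atoms (5 carbon, 1 nitrogen, 1 oxygen, 1 selenium; no ring) in place of a group of 8 heavy atoms (4 carbon, 2 nitrogen, 1 oxygen, 1 selenium; no ring), on an aromatic carbon. The hydrogen-bond donor of the leaving group is gone, and the chain between the aromatic carbon and the selenocyanate is longer.

Within the data shown here, no measured pair shares this change, so its size in this assay can only be estimated. Without a guide from the series, a step from compound 1 to compound 4 of a 1.3-fold lower number from compound 1 to compound 4 (0.10 log units; within the scatter) is expected, which is not beyond the scatter, with either direction possible. Compound 4 is therefore expected to give about 250 nM, within the range 80 nM to 800 nM.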

Compound 4, half-maximal inhibitory concentration: 512 nM
For compound 4 the middle estimate is 2.0-fold (0.31 log units) below the measured one, within the range that was stated.
By their numbers in this assay, from the lowest: compound 2; then compound 3; then compounds 1 and 4 (each within the scatter of the next).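

In this assay, among these compounds, the step of a 1.6-fold higher number from compound 1 to compound 4 (0.21 log units; within the scatter) lies within the scatter, so this is the first single-place comparison, and it separates neither compound from the other. On this aromatic carbon, ortho to a methoxy group, the group of 8 heavy atoms with 5 carbon, 1 nitrogen, 1 oxygen and 1 selenium can therefore stand in place of the group of 8 heavy atoms with 4 carbon, 2 nitrogen, 1 oxygen and 1 selenium without a readable change in this assay, even though the hydrogen-bond donor and the double bond of the leaving group are gone. No measurement is at hand that bears on why the two compounds read alike.

As far as these compounds go, whether a different group at this place, such as a carboxylic acid, an amine or a longer chain ending in the selenocyanate, would move the number beyond the scatter remains open. Among the compounds shown here, also open is which structural difference separates compounds 2 and 3 from compounds 1 and 4, as no single-place step links them.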